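The source may report more compounds than this note shows. Statements on the series, on what has been measured and on what is new or still open speak of the compounds shown alone.

Measured so far in an assay on isolated protein for inhibition of Death-associated protein kinase 3 (Homo sapiens), tested at 1 uM; on this read-out higher numbers stand for a stronger effect at the one concentration tested and lower numbers for a weaker effect:
compound 1 `O=C1OC(c2ccc(Cl)c([N+](=O)[O-])c2)=N/C1=C\c1ccncc1` gives 0%
compound 2 `O=C1OC(c2cccc(Br)c2)=N/C1=C\c1ccncc1` gives 1%
compound 3 `COc1cc(C2=N/C(=C\c3cccnc3)C(=O)O2)cc(OC)c1OC` gives 26%

Compound 2 stands second highest of the three numbers. Its nearest neighbour is compound 1, and the two differ by an amount within the scatter, so they read as the same result. Compound 3 lies well above compound 2, beyond the scatter. Among the measured compounds shown here, no two measured compounds differ in only one place, so no single structural step has a measured size.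

Compound 4 `O=C1OC(c2ccccc2)=N/C1=C\c1ccncc1` has not been measured. Against compound 2 the change is hydrogen in place of bromo on an aromatic carbon, at the place described: on an aromatic carbon of a six-membered aromatic ring of carbon only, meta to a large group. For the measured compounds named here, no measured step of this kind exists here, so the size of the change in this assay has no anchor in the data. With compound 2 at 1% and compound 1 at 0% both giving small numbers on this read-out, the expectation is a step no larger than the scatter, in either direction. The step expected from compound 2 to compound 4 is a number 2 percentage points higher from compound 2 to compound 4 (within the scatter), essentially none. Compound 4 is expected to give 3% in this assay, with a range from -5% to 14%.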

Compound 4, a percentage reported as inhibition, at one concentration (the size of the read-out at that concentration, not a potency): 0%
For compound 4 the middle estimate is 3 percentage points above the measured one; the measured number falls inside the stated range.
By their numbers in this assay, from the lowest: compounds 1, 4 and 2 (each within the scatter of the next); then compound 3.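

In this assay, among the compounds shown here, the step of a number 1 percentage points lower from compound 2 to compound 4 (within the scatter) is the first measured change that sits in one place, with hydrogen in place of bromo on an aromatic carbon, meta to a large group. Taking away this single heavy atom leaves the read-out within the scatter, so bromo and hydrogen cannot be told apart at this place in this pair, and the bromo shows no measurable contribution at the one concentration tested. For the compounds shown here, both numbers are small, so the pair shows only that this change does not raise the read-out from a low level, and nothing measured here bears on why the step is this small.

Going by these compounds, whether an amine or a carboxylic acid on this aromatic carbon would move the number beyond the scatter remains open. Also open, on these data alone, is whether hydrogen in place of bromo would stay this small in a compound with a clearly higher number in this assay, where a loss could be seen as well as a gain.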